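Cyanomethyl for ethoxycarbonyl on the chain at aromatic nitrogen

This account rests on a few compounds, and the source may have more. Where it says the series, first, only, none or still open, it means among the compounds named here.

In a functional assay on MCF7 cells (Homo sapiens) for cytotoxicity, read by colorimetric assay and MTT assay (on this read-out lower numbers stand for stronger inhibition and higher numbers for weaker inhibition), compound 1 `COc1ccc(-c2cc3cccc(OC)c3nc2O)cc1` gives 10000 nM. Compound 2 `CCOC(=O)Cn1c(=O)c(-c2ccc(OC)cc2)cc2c(OC)cc(OC)cc21` gives 10000 nM in this assay, level with compound 1 at the digits shown; the two values lie within the scatter of each other, so no order is read between them. Compound 3 `COc1ccc(-c2cc3c(OC)cc(OC)cc3n(CCC#N)c2=O)cc1` has not been measured. Its difference from compound 2 is cyanomethyl in place of ethoxycarbonyl on a saturated chain carbon bound to an aromatic nitrogen. Going by the values given here, no step between two measured compounds is available, so nothing sets the size of a change on this chain. Compound 1 and compound 2 differ in several places and stand at the same value, which gives no sign that the read-out moves with changes of this kind. In this assay the expected step is no change at the digits printed from compound 2 to compound 3 (within the scatter), none beyond the scatter. Compound 3 is expected to give about 10000 nM in this assay, within a range from 4000 nM to 25000 nM.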

Compound 3, half-maximal inhibitory concentration: 10000 nM
Beside the measured number, compound 3's estimate shows no gap at the digits printed; low and high end bracket the measured number.
By their numbers in this assay, from the lowest: compounds 1, 2 and 3 (each within the scatter of the next).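

Going by these compounds alone, this is the first step read on this chain: in this assay, cyanomethyl in place of ethoxycarbonyl on a saturated chain carbon bound to an aromatic nitrogen gives no change at the digits printed from compound 2 to compound 3 (within the scatter) for the exchange. At this position, then, a nitrile-bearing end with a triple bond takes the place of the ester with its double bond, and compound 3 stays at 10000 nM in this read-out. The ester is therefore not required to hold the value seen for compound 2, though that value gives no step beyond the scatter to build on.

From the compounds shown here alone, whether an amine or a carboxylic acid at the end of this chain, or a longer chain, would move the value remains open. Within the data shown here, the series so far shows no step beyond the scatter, and nothing at hand explains the flat result.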